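The source may hold more compounds than are shown below. What is called first, only, known or untested is meant among the compounds shown, and "the series" means these compounds.

Measured so far:
compound 1 `CC1=C(C(=O)C2CC2)C(c2ccsc2)NC(=O)N1` — 2%
compound 2 `CC1=C(C(=O)SC(C)C)C(c2ccco2)NC(=O)N1` — 5%

Both compounds were run in an assay on membranes from CHO cells for displacement of a labelled ligand from adenosine receptor A1 (Homo sapiens), read by scintillation counting, with a stated time of 60 min, tested at 1 uM; on this read-out higher numbers stand for more inhibition at the one concentration tested (going by the name of the read-out) and lower numbers for less inhibition. Compound 1 gives 2% and compound 2 gives 5%; the two numbers lie within the usual scatter of one another, so neither compound is separated from the other on this read-out, and both sit at the low end of what the assay can report. Among the compounds with values here, no pair of measured compounds differs in only one place, so no measured step is available.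

Compound 3 `CC1=C(C(=O)SC(C)C)C(c2ccsc2)NC(=O)N1` has not yet been measured in this assay. It follows from compound 2 by a change at a single position: thiophen-3-yl in place of furan-2-yl on a saturated ring carbon. This is the exchange of one five-membered aromatic ring with one hetero atom for another of the same kind, with the rest of compound 2 kept.

Within the data shown here, with no measured step to lean on, and the two known numbers in this assay both lying near the bottom of the range, the expected step of no change at the digits printed from compound 2 to compound 3 (within the scatter) is none beyond the scatter. Compound 3 is therefore expected to give 5%, with an estimated range from -5% to 16%.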

Compound 3, a percentage reported as inhibition, at one concentration (the size of the read-out at that concentration, not a potency): 24%
The estimate for compound 3 lay 19 percentage points below the measured number; measured number above the stated range.
By their numbers in this assay, from the lowest: compounds 1 and 2 (each within the scatter of the next); then compound 3.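

In this assay thiophen-3-yl in place of furan-2-yl on a saturated ring carbon gives a number 19 percentage points higher from compound 2 to compound 3 (beyond the scatter) and so shows that this position is sensitive to an exchange between two five-membered aromatic rings with one hetero atom, although the heavy-atom, donor and acceptor counts stay the same. With thiophen-3-yl held in place, isopropylsulfanyl in place of cyclopropyl on a carbonyl carbon gives a number 22 percentage points higher from compound 1 to compound 3 (beyond the scatter) and so shows that the group on the carbonyl also changes the read-out. Nothing available explains either step.

The furan-2-yl to thiophen-3-yl step changes both the hetero atom and the point of attachment, so the compounds shown cannot separate the two; thiophen-2-yl or furan-3-yl at this position would do so. Going by these compounds, each step is also read on one background only, so it remains open whether the gain from thiophen-3-yl extends to other groups on the carbonyl, such as ethoxy or an amine.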